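From Benzoyl to Phenylsulfonyl Against Near-Zero Inhibition

This account rests on a few compounds, and the source may have more. Where it says the series, first, only, none or still open, it means among the compounds named here.

Three compounds have been measured in an assay on isolated protein for inhibition of 3',5'-cyclic-AMP phosphodiesterase 4A (Cavia porcellus), read by cAMP accumulation, tested at 10 uM; a higher number here means a stronger effect of the compound at the concentration tested, a lower number a weaker effect:

Compound 1 `CC(=O)c1cc(C(=O)c2ccccc2)c(=O)[nH]c1C`: 2%
Compound 2 `O=C1CCCc2[nH]c(=O)c(C(=O)c3ccccc3)cc21`: 0%
Compound 3 `O=C1CC(c2ccccc2)Cc2[nH]c(=O)c(C(=O)c3ccccc3)cc21`: 5.2%

On the bare numbers compound 3 stands highest of the three, yet its gaps to compound 1 and to compound 2 are both within the scatter, so the three compounds cannot be told apart in this assay. Within the data shown here, the only step between two compounds differing in one place is a number 5.2 percentage points higher from compound 2 to compound 3 (within the scatter), phenyl in place of hydrogen on a saturated ring carbon, and it also lies within the scatter.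

Compound 4 `O=C1CC(c2ccccc2)Cc2[nH]c(=O)c(S(=O)(=O)c3ccccc3)cc21` differs from compound 3 in this way: phenylsulfonyl in place of benzoyl on an aromatic carbon. Among the measured compounds shown here, no measured step touches the group on that aromatic carbon; the one step recorded concerns a saturated ring carbon and is of no help here. With all three measured numbers near zero and no step beyond the scatter, no move beyond the scatter is expected in this assay. Compound 4 is therefore estimated at 4%, ranging from -5% to 15%, an expected step of a number 1.2 percentage points lower from compound 3 to compound 4 (within the scatter).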

Compound 4, a percentage reported as inhibition, at one concentration (the size of the read-out at that concentration, not a potency): 0%
For compound 4 the middle estimate is 4 percentage points above the measured one, and the stated range covers the measured number.
By their numbers in this assay, from the lowest: compounds 2, 4, 1 and 3 (each within the scatter of the next).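

Among these compounds, the group on this aromatic carbon, two atoms from the ring nitrogen, changes here for the first time, and in this assay phenylsulfonyl in place of benzoyl gives a number 5.2 percentage points lower from compound 3 to compound 4 (within the scatter) and so no readable move. Within this pair, the exchange of the two groups, with the added sulfur and the second double bond outside the aromatic rings, leaves the two compounds indistinguishable, and neither group lifts the read-out clear of the others in the series. Nothing at hand speaks to why the exchange leaves the read-out where it stands.

Going by these compounds, whether any group at this position can raise inhibition at all remains open. An amine or a carboxylic acid on this aromatic carbon, or a longer chain in place of the phenyl on the saturated ring carbon, would be needed to tell.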